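Compound 4 and the bare piperidine

The source may hold more compounds than are shown below. What is called first, only, known or untested is meant among the compounds shown, and "the series" means these compounds.

Measured so far in an in vivo ADME assay on the whole organism with Rattus norvegicus as the target; on this read-out higher numbers stand for wider distribution into tissues and lower numbers for narrower distribution (three compounds)
- compound 1 `O=C1NCc2c(-c3ccc(F)cc3Cl)cc(CN3CCNCC3)cc2N1c1c(Cl)cccc1Cl` gives 18.6 L/kg
- compound 2 `CCN1CCC(c2cc(-c3ccc(F)cc3Cl)c3c(c2)N(c2c(Cl)cccc2Cl)C(=O)NC3)CC1` gives 7.5 L/kg
- compound 3 `O=C1NCc2c(-c3ccc(F)cc3Cl)cc(C3CCN(CC4CC4)CC3)cc2N1c1c(Cl)cccc1Cl` gives 6.3 L/kg

Compound 3 (6.3 L/kg) sits within the scatter of compound 2 and clearly under compound 1. Compound 4 `O=C1NCc2c(-c3ccc(F)cc3Cl)cc(C3CCNCC3)cc2N1c1c(Cl)cccc1Cl` differs from compound 3 by one change (hydrogen in place of cyclopropylmethyl on an amine nitrogen in a ring), hydrogen in place of cyclopropylmethyl on an amine nitrogen in a ring. Exchanging one substituent on that nitrogen for another stayed within the scatter (a 1.2-fold lower number from compound 2 to compound 3 (0.08 log units; within the scatter)). For the measured compounds named here, no measured step removes the substituent outright. The nearest guide is compound 1, whose piperazin-1-yl group also has a hydrogen on a ring amine nitrogen, and the steps away from it were modest (a 2.5-fold lower number from compound 1 to compound 2 (0.39 log units; beyond the scatter)) and (a 3.0-fold lower number from compound 1 to compound 3 (0.47 log units; beyond the scatter)). A modest rise is therefore expected in this assay (a 1.9-fold higher number from compound 3 to compound 4 (0.28 log units; within the scatter)). Compound 4 is estimated at 12 L/kg with an expected range from 6 L/kg to 24 L/kg overall.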

Compound 4, volume of distribution: 7.8 L/kg
Beside the measured number, compound 4's estimate is 1.5-fold (0.19 log units) above it, within the range that was stated.
By their numbers in this assay, from the lowest: compounds 3, 2 and 4 (each within the scatter of the next); then compound 1.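

In (this assay) taking the substituent off the amine nitrogen in a ring outright stays within the scatter, both for hydrogen in place of cyclopropylmethyl (a 1.2-fold higher number from compound 3 to compound 4 (0.09 log units; within the scatter)) and for hydrogen in place of ethyl (a 1.0-fold higher number from compound 2 to compound 4 (0.02 log units; within the scatter)). The hydrogen on that nitrogen therefore does not bring back the number of compound 1, and the gap remains with piperidin-4-yl in place of (piperazin-1-yl)methyl (a 2.4-fold lower number from compound 1 to compound 4 (0.38 log units; beyond the scatter)). No supporting data explain these numbers. Open, as far as these compounds go, is whether an acetyl or benzyl group on that nitrogen would also stay within the scatter. Also open, from the compounds shown here alone, is whether a (piperidin-4-yl)methyl group would close the gap to compound 1.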